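The compounds below may be only part of what the source reports. "The series", "measured", "known", "first", "only" and "open" are said of these compounds alone.

Compound 1 `CC(C)c1nc(N)c2nn(-c3ccccc3)cc2n1` gives 2% in an assay on CHO cells for displacement of a labelled ligand from adenosine receptor A1 (Homo sapiens), read by scintillation counting, tested at 1 uM; on this read-out higher numbers stand for more inhibition at the one concentration tested (going by the name of the read-out) and lower numbers for less inhibition.
Compound 2 `Nc1nc(Cc2ccc(O)cc2)nc2cn(-c3ccccc3)nc12` gives 39% in this assay.

Going by the values given here, compound 2 stands highest of the two numbers; its nearest neighbour is compound 1, and the only measured step, a number 37 percentage points higher from compound 1 to compound 2 (beyond the scatter), is what separates them. Compound 3 `Nc1nc(CCc2ccccc2)nc2cn(-c3ccccc3)nc12` differs from compound 2 by benzyl in place of 4-hydroxyphenyl on a saturated chain carbon bound to an aromatic carbon. Among the compounds with values here, the one step that bears on this change is a number 37 percentage points higher from compound 1 to compound 2 (beyond the scatter), which introduced the whole 4-hydroxybenzyl group in place of isopropyl; it does not separate what the six-membered aromatic ring of carbon only contributes from what the oxygen contributes, so the move to phenethyl cannot be read from it directly. Since compound 3 keeps such a ring but no longer carries the oxygen, a moderate decrease is expected, smaller than the step that built the group: the expected step is a number 14 percentage points lower from compound 2 to compound 3 (beyond the scatter). Compound 3 is therefore estimated at 25%, within 5% to 50%.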

Compound 3, a percentage reported as inhibition, at one concentration (the size of the read-out at that concentration, not a potency): 15%
Compound 3: middle estimate off by 10 percentage points, on the high side; the measured number falls inside the stated range.
By their numbers in this assay, from the lowest: compound 1; then compound 3; then compound 2.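

In this assay, phenethyl retains part of the gain over isopropyl, at a number 13 percentage points higher from compound 1 to compound 3 (beyond the scatter), but it falls short of 4-hydroxybenzyl, with a number 24 percentage points lower from compound 2 to compound 3 (beyond the scatter). A six-membered aromatic ring of carbon only on this aromatic carbon's substituent therefore does not alone account for the number of compound 2, although the change alters the oxygen and the chain together, and the step cannot be assigned to either. No supporting measurement is available to explain this step.

The compounds shown leave open what a plain benzyl group, with the chain of compound 2 but no oxygen, would give. They also leave open whether a methoxy group or an amine on the ring could take the place of the hydroxyl group, or whether a longer chain carrying the hydroxyl group would change the number.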